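Compound 3 to compound 4: chloro in place of methyl

A few compounds are considered here, and "the series" means these few. Any claim that something is new, unique, unknown or untested is made for them only; others in the source may bear on it.

The series is followed in an ADME assay on BHK-21 cells (Mesocricetus auratus) for cytotoxicity, read by MTT assay, with a stated time of 72 h; a higher number here means that more compound is tolerated, a lower number that less compound is tolerated. Compound 1 (`NS(=O)(=O)c1ccc(N2N=C(c3ccc(OCc4ccccc4)cc3)CC2c2ccc(Cl)cc2)cc1`) gives 15000 nM, compound 2 (`Cc1ccc(C2CC(c3ccc(OCc4ccccc4)cc3)=NN2c2ccc(S(N)(=O)=O)cc2)cc1`) gives 32000 nM and compound 3 (`Cc1cccc(C2CC(c3ccc(OCc4ccccc4)cc3)=NN2c2ccc(S(N)(=O)=O)cc2)c1`) gives 8000 nM. Two steps fix the standing of the last of these: a 1.9-fold lower number from compound 1 to compound 3 (0.27 log units; within the scatter), and a 4.0-fold lower number from compound 2 to compound 3 (0.60 log units; beyond the scatter).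

Compound 4 (`NS(=O)(=O)c1ccc(N2N=C(c3ccc(OCc4ccccc4)cc3)CC2c2cccc(Cl)c2)cc1`) carries chloro in place of methyl on an aromatic carbon, 3-methylphenyl to 3-chlorophenyl: chloro in place of methyl on an aromatic carbon. Among the measured compounds shown here, the closest precedent is the same swap run the other way, a 2.1-fold higher number from compound 1 to compound 2 (0.33 log units; beyond the scatter), which read backwards points to a lower number. That is a single pair with the group placed differently, and moving the methyl alone gave a 4.0-fold lower number from compound 2 to compound 3 (0.60 log units; beyond the scatter), so its size need not carry over. A small move to a lower number is therefore expected, not beyond the scatter: a 1.5-fold lower number from compound 3 to compound 4 (0.16 log units; within the scatter). For compound 4 the estimate is 5500 nM, with an expected range of 2500 nM to 14000 nM.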

Compound 4, half-maximal cytotoxic concentration: 45000 nM
Beside the measured number, compound 4's estimate is 8.2-fold (0.91 log units) below it; the measured number lies above the stated range.
By their numbers in this assay, from the lowest: compounds 3 and 1 (each within the scatter of the next); then compounds 2 and 4 (each within the scatter of the next).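

Chloro in place of methyl, as 3-methylphenyl to 3-chlorophenyl, moves the number up in this assay (a 5.6-fold higher number from compound 3 to compound 4 (0.75 log units; beyond the scatter)), opposite to the direction of the same swap in the other placement. The placement of the chloro counts as well, with 3-chlorophenyl in place of 4-chlorophenyl (a 3.0-fold higher number from compound 1 to compound 4 (0.48 log units; beyond the scatter)), the reverse of what moving the methyl did, while the step from the 4-methylphenyl to the 3-chlorophenyl stays within the scatter (a 1.4-fold higher number from compound 2 to compound 4 (0.15 log units; within the scatter)). The swap therefore has no single direction across these compounds, and its two readings disagree: the same change on two cores in this assay, a 2.1-fold higher number (0.33 log units; beyond the scatter) from compound 1 to compound 2 and a 5.6-fold lower number (0.75 log units; beyond the scatter) from compound 4 to compound 3, 12-fold (1.08 log units) apart, beyond the scatter of two such steps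

The compounds shown cover only methyl and chloro in these two placements, so whether a methoxy group, a nitrile or an amine on this aromatic carbon would follow the 3-chlorophenyl or the 3-methylphenyl stays open. What lies behind the reversal is not told by these numbers.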